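A few compounds are considered here, and "the series" means these few. Any claim that something is new, unique, unknown or untested is made for them only; others in the source may bear on it.

Measured so far:
compound 1, `O=C(Nc1cccc(-n2cc(-c3ccncc3)c(-c3ccc(Cl)c(O)c3)n2)c1)Nc1cc(C(F)(F)F)cc(C(F)(F)F)c1`: 480 nM
compound 2, `COc1cc(-c2nn(-c3cccc(NC(=O)c4ccccc4)c3)cc2-c2ccncc2)ccc1Cl`: 850 nM

In a functional assay on RPMI-8226 cells (Homo sapiens) for inhibition, read by sulforhodamine B assay, with a stated time of 48 h (on this read-out lower numbers stand for stronger inhibition and higher numbers for weaker inhibition), compound 1 gives 480 nM. This is the lowest of the two numbers obtained, but the nearest number, that of compound 2 in this assay at 850 nM, lies within the usual scatter of repeated measurements, so no order between compound 1 and compound 2 is claimed. Compound 3, `O=C(Nc1cccc(-n2cc(-c3ccncc3)c(-c3ccc(Cl)c(O)c3)n2)c1)Nc1cccc(C(F)(F)F)c1`, has not yet been measured. It differs from compound 1 in one place: hydrogen in place of trifluoromethyl on an aromatic carbon. Among the compounds with values here, no step between two measured compounds shows the effect of such a change, so the expectation rests on the structures alone. The step is expected to be a 2.1-fold higher number from compound 1 to compound 3 (0.32 log units; beyond the scatter), a modest move toward weaker inhibition, possibly no larger than the scatter. Compound 3 is therefore estimated at 1000 nM, with a range from 400 nM to 2500 nM.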

Compound 3, half-maximal inhibitory concentration: 1340 nM
For compound 3 the middle estimate is 1.3-fold (0.13 log units) below the measured one; the range from low to high includes it.
By their numbers in this assay, from the lowest: compounds 1, 2 and 3 (each within the scatter of the next, the first and the last beyond it).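

In this assay, within the data shown here, hydrogen in place of trifluoromethyl gives a 2.8-fold higher number from compound 1 to compound 3 (0.45 log units; beyond the scatter) and this is the first step here that isolates a single change. It shows that, on this aromatic carbon, meta to a trifluoromethyl group, the change is a modest move toward weaker inhibition that lies beyond the scatter. No measurement given here accounts for the size of this step.

The compounds shown leave open how a nitrile, an amine or a carboxylic acid on this carbon would compare with trifluoromethyl and hydrogen. They also leave open whether replacing the remaining trifluoromethyl group with hydrogen would give a step of similar size, and whether this step would hold on a different core.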